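This account rests on a few compounds, and the source may have more. Where it says the series, first, only, none or still open, it means among the compounds named here.

Compound 1 `Cc1ccc2[nH]c(=O)c(CN(Cc3ccc(F)cc3)Cc3ccc(C(C)(C)C)cc3)cc2c1` — in a toxicity assay on MDCK cells (Canis lupus familiaris) for cytotoxicity, read by crystal violet staining, with a stated time of 48 h (on this read-out higher numbers stand for lower toxicity in this test and lower numbers for higher toxicity in this test), compound 1 gives > 27000 nM, which is a limit of the assay rather than a number.
Compound 2 `COCOc1ccc(CN(Cc2ccc(C(C)(C)C)cc2)Cc2cc3cc(C)ccc3[nH]c2=O)cc1` — in this assay compound 2 gives 6400 nM.
Compound 3 `Cc1ccc2[nH]c(=O)c(CN(Cc3ccc(O)cc3)Cc3ccc(C(C)(C)C)cc3)cc2c1` — in this assay compound 3 gives 4900 nM.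

Compound 3 holds the lowest of the two numbers obtained, with compound 2 nearest; the step of a 1.3-fold lower number from compound 2 to compound 3 (0.12 log units; within the scatter) lies within the scatter, so no order between compound 2 and compound 3 can be claimed. Against compound 1 both steps, an at least 4.2-fold lower number from compound 1 to compound 2 (0.62 log units; beyond the scatter) and an at least 5.5-fold lower number from compound 1 to compound 3 (0.74 log units; beyond the scatter), are beyond the scatter.

Compound 4 `Cc1ccc2[nH]c(=O)c(CN(Cc3ccc(OCC(=O)OC(C)(C)C)cc3)Cc3ccc(C(C)(C)C)cc3)cc2c1` differs from compound 3 by (tert-butoxycarbonyl)methyl in place of hydrogen on an oxygen on an aromatic ring. Among the compounds with values here, the step that bears on this change is the one from compound 2 to compound 3, in which a group on the same oxygen was exchanged for hydrogen with a result within the scatter. The step of a 1.4-fold higher number from compound 3 to compound 4 (0.15 log units; within the scatter) is therefore expected to stay within the scatter. For compound 4 the estimate in this assay is 7000 nM, between 3000 nM and 20000 nM.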

Compound 4, half-maximal cytotoxic concentration: > 10000 nM
Compound 4: only a limit was reported (the forecaster's own chance of this, stated with the estimate: 15%); middle value at least 1.4-fold (0.15 log units) away from the limit.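

In this assay compound 4 gives > 10000 nM, which is a limit of the assay and not a number. The exchange of methoxymethyl for hydrogen on this oxygen gave a result within the scatter, and (tert-butoxycarbonyl)methyl on the same oxygen now gives only floors, an at least 2.0-fold higher number from compound 3 to compound 4 (0.30 log units; that floor lies within the scatter) and an at least 1.5-fold higher number from compound 2 to compound 4 (0.19 log units; that floor lies within the scatter), so neither step shows a real change, yet neither excludes one. Two limits stand against each other from compound 1 to compound 4, and that step cannot be read.

As far as these compounds go, the true place of compound 4 relative to compound 2 and compound 3 remains open. From the compounds shown here alone, how a carboxylic acid or an amine carried on this oxygen on an aromatic ring would read in this assay also remains open.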